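The compounds below may be only part of what the source reports. "The series", "measured", "known", "first", "only" and "open" are said of these compounds alone.

Measured so far:
Compound 1 `Cc1onc(NS(=O)(=O)c2ccc(N)cc2)c1I` — in an assay on A7R5 cells for displacement of a labelled ligand from Endothelin-1 receptor (Rattus norvegicus) (on this read-out higher numbers stand for weaker inhibition and lower numbers for stronger inhibition), compound 1 gives 11000 nM.
Compound 2 `CSc1c(NS(=O)(=O)c2ccc(C(C)(C)C)cc2)noc1C` — in this assay compound 2 gives > 100000 nM, which is a limit of the assay and not a number.
Compound 3 `Cc1nsc(NS(=O)(=O)c2ccc(C(C)(C)C)cc2)c1C` — in this assay compound 3 gives > 500000 nM, again only a limit.

Compound 3 therefore sits at the limit of > 500000 nM in this assay, at which 1 of the 3 values shown sits, so its true strength of inhibition is not pinned to a number. Compound 2 sits at the limit of > 100000 nM in this assay, at which 1 of the 3 values shown sits. Only compound 1 has a measured number. For the measured compounds named here, no two measured compounds differ in a single place, so no step size can be read from the measurements.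

The unmeasured compound 4 `Cc1onc(NS(=O)(=O)c2ccc(C(C)(C)C)cc2)c1I` differs from compound 3 by 4-iodo-5-methyl-1,2-oxazol-3-yl in place of 3,4-dimethyl-1,2-thiazol-5-yl on a sulfonamide nitrogen. Going by the values given here, the heterocycle that enters is the one carried by compound 1, whose measured value 11000 nM is the only real number in the set, while the remainder of compound 4 matches compounds 2 and 3. The expected step is an at least 16-fold lower number from compound 3 to compound 4 (1.22 log units; beyond the scatter), toward stronger inhibition, though whether it reaches a measurable number is uncertain. Compound 4 is expected to give about 30000 nM, within 5000 nM to 300000 nM.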

Compound 4, half-maximal inhibitory concentration: > 100000 nM
Compound 4: only a limit was reported; the forecaster's own chance of this, stated with the estimate: 35%; middle value at least 3.3-fold (0.52 log units) away from the limit.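

For the compounds shown here, the heterocycle of compound 1 does not carry a measurable number on its own: with it held fixed, tert-butyl in place of amino on an aromatic carbon gives an at least 9.0-fold higher number from compound 1 to compound 4 (0.95 log units; beyond the scatter) in this assay, the first step in this set that can be read. Compound 4 gives only a limit and not a number: the limit of > 100000 nM in this assay, at which 2 of the 4 values shown sit. The steps to compound 4 from compound 2 and from compound 3 have limits at both ends and cannot be read.

From the compounds shown here alone, how far the step from amino to tert-butyl really reaches stays open, as does whether the choice of heterocycle matters at all while tert-butyl is present. A methoxy group or a carboxylic acid on that aromatic carbon would show whether inhibition depends on amino specifically.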